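A few compounds are considered here, and "the series" means these few. Any claim that something is new, unique, unknown or untested is made for them only; others in the source may bear on it.

In a functional assay on A549 cells (Homo sapiens) for inhibition, read by sulforhodamine B assay (on this read-out higher numbers stand for weaker inhibition of growth and lower numbers for stronger inhibition of growth), compound 1 `c1ccc(-c2ccc(-c3ccc(-c4nc5ccccc5[nH]4)cc3)cc2)cc1` gives 41200 nM and compound 2 `CN(C)c1ccc(-c2ccc(-c3ccc(-c4nc5ccccc5[nH]4)cc3)cc2)cc1` gives 30100 nM while compound 3 `Oc1cccc2[nH]c(-c3ccc(-c4ccc(-c5ccccc5)cc4)cc3)nc12` gives 8320 nM as the lowest of the three numbers. The next compound to be read is compound 4 `Oc1cccc2[nH]c(-c3ccc(-c4ccc(-c5cccc(Cl)c5)cc4)cc3)nc12`. It differs from compound 3 by chloro in place of hydrogen on an aromatic carbon with chloro in place of hydrogen on an aromatic carbon, meta to a large group.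

For the measured compounds named here, two measured steps bear on this change, and neither involves chloro. Dimethylamino on the ring that takes the chloro gave a 1.4-fold lower number from compound 1 to compound 2 (0.14 log units; within the scatter) and is the closer precedent in place. Hydroxy on another ring gave a 5.0-fold lower number from compound 1 to compound 3 (0.69 log units; beyond the scatter) and shows that one added group can move this read-out by a modest amount. On these data alone, neither step starts from compound 3, so whether the hydroxy step carries over to a further substitution remains open. Only the hydroxy step lies beyond the scatter, and compound 2 goes against any general lowering on substitution. A small move to a lower number is therefore expected, with no clear shift beyond the scatter. The expected change is a 1.4-fold lower number from compound 3 to compound 4 (0.14 log units; within the scatter) on this estimate. The estimated value for compound 4 is 6000 nM with an expected range from 2500 nM to 15000 nM in this assay for now.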

Compound 4, concentration for 50% growth inhibition: 2400 nM
The estimate for compound 4 lay 2.5-fold (0.40 log units) above the measured number; measured number below the stated range.
By their numbers in this assay, from the lowest: compound 4; then compound 3; then compounds 2 and 1 (each within the scatter of the next).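

In this assay the step is a 3.5-fold lower number from compound 3 to compound 4 (0.54 log units; beyond the scatter) and it shows that the phenyl ring becoming 3-chlorophenyl can move this read-out beyond the scatter through a single added chloro, on a parent that already carries the hydroxy. The dimethylamino step on that same ring reads a 1.4-fold lower number from compound 1 to compound 2 (0.14 log units; within the scatter) and stayed within the scatter, but it started from a parent without the hydroxy, so it did not show how this ring behaves on the hydroxy parent. No measurement at hand accounts for the lower number with chloro.

The compounds shown leave open whether this step belongs to chloro itself or to the place it occupies, since fluoro, methyl, methoxy, an amine or a carboxylic acid on the same carbon cannot be compared with it here, and chloro on the other carbons of that ring is equally unknown. They also leave open whether chloro would give a similar step on compound 1, without the hydroxy, or whether the hydroxy and chloro steps simply add up in this series.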